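Swapping a fluorophenyl for an ethylphenyl in a weak series

The compounds below may be only part of what the source reports. "The series", "measured", "known", "first", "only" and "open" are said of these compounds alone.

Measured compounds:
compound 1, `COc1ccc(-n2cnc3cnc(Nc4cccc(NS(C)(=O)=O)c4)cc32)cc1OC`, 6900 nM
compound 2, `Cc1cc(F)ccc1-c1cc2c(cn1)ncn2-c1ccc(O)nc1`, limit of > 10000 nM
compound 3, `Fc1ccc(-c2cc3c(cn2)ncn3-c2ccc(OC(F)F)cc2)cc1`, 10000 nM

All three compounds share a core and were tested in a functional assay on HL-60 cells (Homo sapiens) for activation, read by flow cytometry, with a stated time of 4 days; on this read-out higher numbers stand for an effect only at larger amounts of compound and lower numbers for an effect already at smaller amounts. Compound 1 gives 6900 nM. Compound 3 gives 10000 nM, the highest of the two numbers shown, though the gap to compound 1 lies within the scatter, so the two cannot be told apart. Compound 2 reaches only a limit of the assay, > 10000 nM, and no number is known for it (the limit of > 10000 nM in this assay, at which 1 of the 3 values shown sits).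

Compound 4, `CCc1ccccc1-c1cc2c(cn1)ncn2-c1ccc(OC(F)F)cc1`, has not yet been measured. It differs from compound 3 in one place: 2-ethylphenyl in place of 4-fluorophenyl on an aromatic carbon. The group that leaves and the group that enters are both single six-membered aromatic rings of carbon only, with neither hydrogen-bond donors nor acceptors, so the change is small on paper. Going by the values given here, no pair of measured compounds shows what such a change does here.

With compound 3 already at the edge of what this assay resolves, no step beyond the scatter is expected in either direction; compound 4 is estimated at 10000 nM, between 3000 nM and 30000 nM, which means a step of no change at the digits printed from compound 3 to compound 4 (within the scatter), and there is a real chance that only a limit is reported.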

Compound 4, half-maximal effective concentration: 2900 nM
Compound 4: the middle estimate sits 3.4-fold (0.54 log units) above what was measured, outside the stated range (below it).
By their numbers in this assay, from the lowest: compound 4; then compounds 1 and 3 (each within the scatter of the next).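

In this assay, 2-ethylphenyl in place of 4-fluorophenyl gives a 3.4-fold lower number from compound 3 to compound 4 (0.54 log units; beyond the scatter). Going by these compounds alone, the earlier compounds offered no pair differing in one place, so this is the first sign that the ring on this aromatic carbon can move the number, and the move is modest but beyond the scatter. It also shows that two rings with much the same counts, both six-membered, all carbon and without hydrogen-bond donors or acceptors, need not behave alike here, though this is a single pair in a weak series, in which compound 2 stays a limit: the limit of > 10000 nM in this assay, at which 1 of the 4 values shown sits.

One pair cannot separate the arrival of the ethyl group from its place on the ring or from the loss of the fluorine, and it gives no reason for the step. From the compounds shown here alone, what a plain phenyl, a phenyl with a longer chain such as propyl, or a phenyl carrying an amine or a carboxylic acid would do on this same carbon stays open.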